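This account rests on a few compounds, and the source may have more. Where it says the series, first, only, none or still open, it means among the compounds named here.

Measured so far in an assay on isolated protein for inhibition of DNA topoisomerase 1 (Homo sapiens), with a stated time of 30 min, tested at 20 uM; on this read-out lower numbers stand for a weaker effect and higher numbers for a stronger effect at the one concentration tested:
- compound 1, `Cc1ccc2c(=O)[nH]c(-c3ccccc3N(C)C)nc2c1`: compound 1 gives 5.3%
- compound 2, `COc1cccc(-c2nc3cc(C)ccc3c(=O)[nH]2)c1`: compound 2 gives 80%

Compound 1 stands lowest of the two numbers. Within the data shown here, its only neighbour, compound 2, sits well above it, a gap that lies beyond the scatter. Among the measured compounds shown here, no pair of measured compounds differs in one place, so nothing more can be read than that the shared core gives a small read-out with one pendant group and a large one with another.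

Compound 3, `Cc1ccc2c(=O)[nH]c(-c3ccccc3F)nc2c1`, is the next compound to be measured. It differs from compound 1 by fluoro in place of dimethylamino on an aromatic carbon. Compound 2 gives the only indication that a small group on the pendant ring can go with a high value, but its group sits at a different position, so the step from compound 1 is largely open. An upward step of moderate size, about at the edge of the scatter, is expected, with wide uncertainty on either side; the expected step is a number 19.7 percentage points higher from compound 1 to compound 3 (beyond the scatter). For compound 3 the estimate in this assay is 25%, within a range from 5% to 60%.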

Compound 3, a percentage reported as inhibition, at one concentration (the size of the read-out at that concentration, not a potency): 0%
Compound 3: the middle estimate sits 25 percentage points above what was measured, and the stated range ends above it.
By their numbers in this assay, from the lowest: compounds 3 and 1 (each within the scatter of the next); then compound 2.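

At this aromatic carbon, ortho to a large group, fluoro in place of dimethylamino gives a number 5.3 percentage points lower from compound 1 to compound 3 (within the scatter) in this assay, so the two groups cannot be told apart on this read-out. The read-out at this position therefore does not follow the differences counted between the two groups: dimethylamino brings more heavy atoms and a hydrogen-bond acceptor, fluoro a single heavy atom and no acceptor, and the step between them stays within the scatter. No measurement at hand bears on why the two compounds read alike.

Going by these compounds, it remains open whether any group on this aromatic carbon can lift the read-out, for instance a hydroxyl, a primary amine or a carboxylic acid, or whether the value stays in this range whatever stands there. Also open, on these data alone, is how a methoxy on this same carbon would read against compound 3, and whether a longer chain such as ethoxy would give the same result, since only a step that changes one place can settle these questions.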